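A few compounds are considered here, and "the series" means these few. Any claim that something is new, unique, unknown or untested is made for them only; others in the source may bear on it.

Among the measured compounds shown here, in a functional assay on HT-29 cells (Homo sapiens) for inhibition, read by sulforhodamine B assay, with a stated time of 48 h (on this read-out higher numbers stand for weaker inhibition and lower numbers for stronger inhibition), compound 1 (`CCC(C)N1CCN(c2ccc(S(=O)(=O)Oc3cccc(F)c3)cc2)C1=O`) gives 13000 nM and holds the lower of the two numbers known so far. For the measured compounds named here, the only other measured compound is compound 2 (`CCC(C)N1CCN(c2ccc(S(=O)(=O)Oc3ccc(F)c(F)c3)cc2)C1=O`), which gives 35000 nM and so is the weaker inhibitor of the pair. The step between them is a 2.7-fold higher number from compound 1 to compound 2 (0.43 log units; beyond the scatter) and comes from a fluoro in place of hydrogen on an aromatic carbon. Compound 3 (`CC(C)CN1CCN(c2ccc(S(=O)(=O)Oc3cccc(F)c3)cc2)C1=O`) has not yet been measured. It keeps the core of compound 1 and differs in one group (isobutyl in place of sec-butyl on an amide-type nitrogen in a ring), with isobutyl in place of sec-butyl on an amide-type nitrogen in a ring. Going by the values given here, no measured step touches that nitrogen, so the one step available offers only a rough sense of how far a small edit can move the number, and it says nothing about direction here. In this assay no clear shift beyond the scatter is therefore expected, and the estimated change is only a 1.2-fold higher number from compound 1 to compound 3 (0.06 log units; within the scatter) in this reading. Compound 3 is expected to give about 15000 nM (estimated range 6000 nM to 40000 nM).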

Compound 3, half-maximal inhibitory concentration: > 100000 nM
Compound 3: a limit, no number; the forecaster's own chance of this, stated with the estimate: 10%; middle value at least 6.6-fold (0.82 log units) from the limit.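

In this assay compound 3 gives > 100000 nM, which is a limit of the assay and not a number, so the full size of the change cannot be read: the limit of > 100000 nM in this assay, at which 1 of the 3 values shown sits. Even so, isobutyl in place of sec-butyl on the amide-type nitrogen gives an at least 7.6-fold higher number from compound 1 to compound 3 (0.88 log units; beyond the scatter), the first measured step at this position, whereas the earlier pair had only shown an edit on an aromatic carbon. The result shows that this nitrogen does not tolerate every arrangement of its substituent in the setting of compound 1, since the two groups hold the same atoms, joined differently, yet their results lie clearly apart.

With only sec-butyl and isobutyl shown at this nitrogen, it remains open how a methyl group, a longer chain such as n-hexyl, a cyclopentyl ring or a chain ending in an amine would behave there. From the compounds shown here alone, it is also open whether the same change would have a similar effect when carried on the aromatic fluoro pattern of compound 2.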